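The compounds below may be only part of what the source reports. "The series", "measured", "known", "first", "only" and "open" are said of these compounds alone.

Measured so far:
compound 1 `CC(=O)N1CCN(S(=O)(=O)c2ccc(F)cc2)CC1` — >= 4 h
compound 2 `CC(=O)N1CCN(S(=O)(=O)c2ccc(F)cc2)CC1CO` — >= 4 h
compound 3 `CCOC(=O)C1CN(S(=O)(=O)c2ccc(F)cc2)CCN1C(C)=O` — 0.617 h

In an ADME assay on a cell-free system (plasma, Rattus norvegicus, strain Sprague-Dawley) for metabolic stability, read by LC-MS, tested at 1 uM (on this read-out higher numbers stand for a longer-lived compound and lower numbers for a shorter-lived compound), compound 1 gives >= 4 h, which is a limit of the assay and not a number. Compound 2 likewise reaches only a limit, >= 4 h. Compound 3 gives 0.617 h. The two limits leave a step that the two limits leave unreadable from compound 1 to compound 2 unreadable, whereas an at least 6.4-fold lower number from compound 1 to compound 3 (0.81 log units; beyond the scatter) and an at least 6.4-fold lower number from compound 2 to compound 3 (0.81 log units; beyond the scatter) are clearly read. Compound 4 `CCOC(=O)C1CN(C(C)=O)CCN1S(=O)(=O)c1ccc(F)cc1` differs from compound 1 by ethoxycarbonyl in place of hydrogen on a saturated ring carbon. The same entering group, taken up elsewhere on the shared core, gave an at least 6.4-fold lower number from compound 1 to compound 3 (0.81 log units; beyond the scatter), so a drop of similar size is expected in this assay. Compound 4 is therefore estimated at 0.7 h, between 0.25 h and 2.5 h, which would mean an at least 5.7-fold lower number from compound 1 to compound 4 (0.75 log units; beyond the scatter).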

Compound 4, half-life in the plasma assay: 0.35 h
Compound 4: middle estimate off by 2.0-fold (0.30 log units), on the high side, within the range that was stated.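

In the plasma assay, ethoxycarbonyl on the saturated ring carbon next to the ring atom that bears a large group gives an at least 11-fold lower number from compound 1 to compound 4 (1.05 log units; beyond the scatter), so the drop seen with compound 3 is not confined to one place on the shared core. In a physicochemical assay for metabolic stability, read by LC-MS, in phosphate buffer, tested at 1 uM (on this read-out higher numbers stand for a longer-lived compound and lower numbers for a shorter-lived compound), compound 1 gives >= 4 h, which is a limit of the assay and not a number. In the physicochemical assay compound 4 gives >= 4 h, which is a limit of the assay and not a number. The step from compound 1 in that assay cannot be read, as both compounds sit at the same limit: the limit of >= 4 h in the physicochemical assay, at which 2 of the 2 values shown sit.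

On these data alone, it remains open which part of ethoxycarbonyl the drop in the plasma assay depends on. As far as these compounds go, it also remains open whether a carboxylic acid or a longer chain at this place would give a similar half-life.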